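This account rests on a few compounds, and the source may have more. Where it says the series, first, only, none or still open, it means among the compounds named here.

Measured in a functional assay on HEK293 cells for agonist activity at D(4) dopamine receptor (Homo sapiens), read by FLIPR; on this read-out lower numbers stand for an effect already at smaller amounts and higher numbers for an effect only at larger amounts of compound:

compound 1 `Cc1cccc(NC(=O)CN2CCC(c3ccccc3C#N)CC2)c1`: 8 nM
compound 2 `Cc1ccc(C(=O)NCN2CCC(c3cccc[n+]3[O-])CC2)cc1C`: 38 nM
compound 3 `Cc1cc(C)cc(NC(=O)CN2CCC(c3cccc[n+]3[O-])CC2)c1`: 52 nM

Compound 3 stands at the highest of the three numbers. Its distance to compound 2 lies within the usual scatter of this kind of measurement, so no order between these two can be read from the values shown. Compound 1 gives a number clearly lower than that of compound 3, a gap beyond the scatter; compound 1 differs from compound 3 in more than one place, so nothing in it isolates a single change.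

Compound 4 `CSc1cccc(NC(=O)CN2CCC(c3cccc[n+]3[O-])CC2)c1` is the next member. Against compound 3 the difference is 3-(methylsulfanyl)phenyl in place of 3,5-dimethylphenyl on an amide-type nitrogen. Among the measured compounds shown here, no pair of measured compounds carries this change alone, so there is no measured step to lean on. With the amide-type nitrogen, the carbonyl and the rest of the shared core unchanged, the expected step from compound 3 to compound 4 in this assay is small, a 1.3-fold lower number from compound 3 to compound 4 (0.11 log units; within the scatter), not beyond the scatter, and if anything toward a lower number. For compound 4 the estimate in this assay is therefore 40 nM, in a range from 12 nM to 130 nM.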

Compound 4, half-maximal effective concentration: 100 nM
Estimate against measurement, compound 4: 2.5-fold (0.40 log units) below; the range from low to high includes it.
By their numbers in this assay, from the lowest: compound 1; then compounds 2, 3 and 4 (each within the scatter of the next, the first and the last beyond it).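

In this assay, among the compounds shown here, 3-(methylsulfanyl)phenyl in place of 3,5-dimethylphenyl on an amide-type nitrogen gives a 1.9-fold higher number from compound 3 to compound 4 (0.28 log units; within the scatter), the first comparison that isolates a change in one place. At this position, therefore, the sulfur-bearing group and the dimethyl-substituted group cannot be told apart by this read-out, and no order between them can be drawn. Nothing available accounts for the size of this step.

For the compounds shown here, the single exchange leaves open how far this position tolerates other groups, such as a carboxylic acid, a primary amine or a longer alkyl chain on the phenyl ring. Also open, as far as these compounds go, is whether 3-(methylsulfanyl)phenyl would give a similar result on the rest of the structure of compound 1.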